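The compounds below may be only part of what the source reports. "The series", "measured", "known", "first", "only" and "open" are said of these compounds alone.

Measured compounds and their values in an assay on HEK293 cells for agonist activity at transient receptor potential cation channel subfamily M member 8 (Homo sapiens), read by fluorescence and calcium flux, with a stated time of 15 min; a higher number here means that more compound is needed for the effect, a lower number that less compound is needed:

compound 1, `Cc1ccc(OCC(=O)N(Cc2cccs2)c2ccnn2C)cc1`: 422 nM
compound 2, `Cc1ccc(OCC(=O)N(Cc2cccs2)C2COC2)cc1`: 23000 nM
compound 3, `Cc1ccc(OCC(=O)N(C)Cc2cccs2)cc1`: 400 nM

All three compounds share one core and differ only in the group carried on the amide-type nitrogen. Compound 3 carries a methyl there and gives the lowest of the three numbers in this assay; compound 1 sits essentially beside it, since the step of a 1.1-fold lower number from compound 1 to compound 3 (0.02 log units; within the scatter) lies within the scatter, whereas compound 2 with its oxetan-3-yl lies far away, as the step of a 58-fold lower number from compound 2 to compound 3 (1.76 log units; beyond the scatter) shows.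

Compound 4, `Cc1ccc(OCC(=O)N(Cc2cccs2)c2ccncc2)cc1`, is the next step from compound 3: pyridin-4-yl in place of methyl on an amide-type nitrogen. Within the data shown here, two measured steps bear on this. The step of a 1.1-fold lower number from compound 1 to compound 3 (0.02 log units; within the scatter) shows that a heteroaromatic ring on this nitrogen, the 1-methyl-1H-pyrazol-5-yl of compound 1, is tolerated as well as a methyl; the step of a 58-fold lower number from compound 2 to compound 3 (1.76 log units; beyond the scatter) shows that a saturated oxetan-3-yl ring is not. Pyridin-4-yl is an aromatic ring, closer in kind to the former than to the latter, so the expected step of a 1.3-fold higher number from compound 3 to compound 4 (0.10 log units; within the scatter) is small, in either direction, and may not exceed the scatter. Compound 4 is therefore expected to give about 500 nM, with a range from 150 nM to 2000 nM.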

Compound 4, half-maximal effective concentration: 52 nM
Compound 4: the middle estimate sits 9.6-fold (0.98 log units) above what was measured, and the stated range ends above it.
By their numbers in this assay, from the lowest: compound 4; then compounds 3 and 1 (each within the scatter of the next); then compound 2.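

In this assay, the step of a 7.7-fold lower number from compound 3 to compound 4 (0.89 log units; beyond the scatter) shows that this amide-type nitrogen does more than tolerate an aromatic ring, since a ring here can bring the number clearly under that of the methyl. The step of an 8.1-fold lower number from compound 1 to compound 4 (0.91 log units; beyond the scatter) shows that the kind of ring counts as well: pyridin-4-yl and 1-methyl-1H-pyrazol-5-yl are both aromatic, yet they are not interchangeable here, and the step of a 440-fold lower number from compound 2 to compound 4 (2.65 log units; beyond the scatter) widens the span seen at this single position, from oxetan-3-yl to pyridin-4-yl. Nothing measured here explains why pyridin-4-yl stands apart from the other groups on this nitrogen.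

As far as these compounds go, it remains open whether the ring nitrogen of pyridin-4-yl matters at all, which a plain phenyl would test, and whether its place in the ring matters, which pyridin-3-yl or pyridin-2-yl would test. It is also open whether the same gain would hold if the shared core were altered elsewhere, as every compound shown differs only on this one nitrogen.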